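This account rests on a few compounds, and the source may have more. Where it says the series, first, only, none or still open, it means among the compounds named here.

Four compounds from one study share a core and differ in the groups attached to it. Compound 1 `CC1=C(C(=O)Nc2ccc(F)cc2)C(c2ccc([N+](=O)[O-])cc2)N=C(SCc2ccccc2)N1` carries a benzylsulfanyl group and a plain benzyl; compound 2 `CC1=C(C(=O)Nc2ccc(F)cc2)C(c2ccc([N+](=O)[O-])cc2)N=C(SCc2ccccc2Cl)N1` is the same molecule with one change, (chloro in place of hydrogen on an aromatic carbon). Compound 3 `CC1=C(C(=O)Nc2ccc(Br)cc2)C(c2ccc(Cl)cc2Cl)N=C(SCc2ccccc2)N1` has a different set of substituents on the core; how its core differs from that of compound 1 is not broken down here. Compound 4 `CC1=C(C(=O)Nc2ccc(Br)cc2)C(c2ccc(Cl)cc2Cl)N=C(SCc2ccccc2Cl)N1` stands to compound 3 as compound 2 stands to compound 1, the change being (chloro in place of hydrogen on an aromatic carbon), so the two changes sit at the same place and are the same change.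

In a functional assay on the whole organism (artery, strain albino) with Rattus norvegicus as the target, with a stated time of 360 min, at a dose of 10 mg/kg by the oral route (a higher number here means more inhibition at the dose given (going by the name of the read-out), a lower number less inhibition), compound 1 gives 38.7%. Compound 2 gives 21.6% in this assay, so the change made a step of a number 17.1 percentage points lower from compound 1 to compound 2 (beyond the scatter). Compound 3 gives 24.2%; its value sits within the scatter of compound 2 and beyond the scatter below compound 1.

Within the data shown here, only one earlier measurement of this change exists, and it was made on a different core, so whether it carries over to compound 3 is not known. Taking it as the only guide, compound 4 is expected to give a lower inhibition than compound 3, by roughly a step of a number 14.2 percentage points lower from compound 3 to compound 4 (beyond the scatter), because the earlier change produced a number 17.1 percentage points lower from compound 1 to compound 2 (beyond the scatter). Among the measured compounds shown here, on that basis compound 4 is estimated at 10% in this assay, with a likely range from 0% to 27%, the width reflecting the single precedent.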

Compound 4, a percentage reported as inhibition, in the whole organism at one dose (the size of the read-out at that dose, not a potency): 38.1%
The estimate for compound 4 lay 28.1 percentage points below the measured number; measured number above the stated range.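

In this assay, replacing benzyl with 2-chlorobenzyl gave a number 13.9 percentage points higher from compound 3 to compound 4 (beyond the scatter), so on this core the change went with more inhibition, whereas on the core of compound 1 it went with less. Among these compounds, the effect of this change therefore cannot simply be carried from one core to the other, as the two steps set side by side make plain: the same change on two cores in this assay, a number 17.1 percentage points lower (beyond the scatter) from compound 1 to compound 2 and a number 13.9 percentage points higher (beyond the scatter) from compound 3 to compound 4, 31 percentage points apart, beyond the scatter of two such steps This does not show which feature of the cores matters, since they differ in more than one group, and with only two pairs, each read at a single dose, it gives no general rule for the change and no measure of potency.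

The compounds shown leave open whether the difference in the step follows the fluorophenyl or bromophenyl group on the amide, or the nitrophenyl or dichlorophenyl group on the core, as these groups change together between the two pairs. They also leave open how another group in place of the chloro, such as a methoxy group or an amine, would behave on either core.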